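The source may report more compounds than this note shows. Statements on the series, on what has been measured and on what is new or still open speak of the compounds shown alone.

Measured in an assay on isolated protein for inhibition of histone deacetylase 8 (Homo sapiens), with a stated time of 1 h; on this read-out higher numbers stand for weaker inhibition and lower numbers for stronger inhibition:
compound 1 `O=C(COc1ccc2cc(/C=C3/SC(=O)NC3=O)ccc2c1)Nc1ccccn1` — > 50000 nM (a limit)
compound 2 `O=C(COc1ccc2cc(/C=C3/SC(=O)NC3=O)ccc2c1)Nc1ccccc1` — 4500 nM
compound 3 `O=C(COc1ccc2cc(/C=C3/SC(=O)NC3=O)ccc2c1)Nc1cccc(C(F)(F)F)c1` — > 50000 nM (a limit)

Compound 3 stands at a limit of this assay, > 50000 nM, not at a number. Compound 1 likewise sits at a limit, > 50000 nM. Among the measured compounds shown here, compound 2 gives the only number in the set, 4500 nM. The step of an at least 11-fold lower number from compound 1 to compound 2 (1.04 log units; beyond the scatter) and the step of an at least 11-fold higher number from compound 2 to compound 3 (1.04 log units; beyond the scatter) are both beyond the scatter, while the step that the two limits leave unreadable from compound 1 to compound 3 cannot be read; both limits sit at the limit of > 50000 nM in this assay, at which 2 of the 3 values shown sit.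

Compound 4 `O=C(COc1ccc2cc(/C=C3/SC(=O)NC3=O)ccc2c1)Nc1ccc([N+](=O)[O-])cc1` differs from compound 3 by 4-nitrophenyl in place of 3-(trifluoromethyl)phenyl on an amide-type nitrogen. For the measured compounds named here, no measured step swaps one substituted phenyl for another. The step of an at least 11-fold higher number from compound 2 to compound 3 (1.04 log units; beyond the scatter) shows that placing a substituent on the phenyl of compound 2 drives the number to a limit, and compound 3 starts at that limit. A step of an at least 1.6-fold lower number from compound 3 to compound 4 (0.22 log units; that floor lies within the scatter) is therefore expected, with a high chance of another limit. Compound 4 is estimated at 30000 nM, within 5000 nM to 200000 nM.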

Compound 4, half-maximal inhibitory concentration: 4000 nM
For compound 4 the middle estimate is 7.5-fold (0.88 log units) above the measured one; the measured number lies below the stated range.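

A substituent on the phenyl does not by itself remove inhibition in this assay: 4-nitrophenyl on the amide-type nitrogen shows a 1.1-fold lower number from compound 2 to compound 4 (0.05 log units; within the scatter). Compound 3 is thus the one case here of a substituted phenyl at a limit, and compound 4 separates clearly from it, with an at least 12-fold lower number from compound 3 to compound 4 (1.09 log units; beyond the scatter). The same holds for the pyridin-2-yl compound, with an at least 12-fold lower number from compound 1 to compound 4 (1.09 log units; beyond the scatter), and both of these steps start from a limit: the limit of > 50000 nM in this assay, at which 2 of the 4 values shown sit.

From the compounds shown here alone, whether the gap follows the group itself or its place on the phenyl stays open. Going by these compounds, how an amine or a carboxylic acid on the phenyl would read also stays open.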